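Cytotoxicity notes: from compound 2 to compound 3

The compounds below may be only part of what the source reports. "The series", "measured", "known", "first", "only" and "open" are said of these compounds alone.

- compound 1 `COC(=O)/C=C/CNC(=O)c1cccc2c1NCCC2`: > 30000 nM
- compound 2 `COC(=O)CCCNC(=O)c1cccc2c1NC(C)(C)C[C@H]2C`: > 30000 nM

In an ADME assay on Vero C1008 cells (Chlorocebus sabaeus) for cytotoxicity (on this read-out higher numbers stand for lower toxicity in this test and lower numbers for higher toxicity in this test), compound 2 stands at > 30000 nM, which is a limit and not a number. Among the compounds with values here, the series so far shows (the limit of > 30000 nM in this assay, at which 2 of the 2 values shown sit). Compound 3 `COC(=O)/C=C/CNC(=O)c1cccc2c1NC(C)(C)C[C@H]2C` carries 2-(methoxycarbonyl)ethenyl in place of 2-(methoxycarbonyl)ethyl on a saturated chain carbon bound to an amide-type nitrogen. The same 3-(methoxycarbonyl)prop-2-en-1-yl chain on the core of compound 1 gives > 30000 nM, so no change beyond the scatter is expected in this assay. The expected change is a number no higher from compound 2 to compound 3 (the limit leaves the size open). The estimated value for compound 3 is 30000 nM, with an expected range from 12000 nM to 60000 nM.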

Compound 3, half-maximal cytotoxic concentration: > 30000 nM
Compound 3: only a limit was reported; the forecaster's own chance of this, stated with the estimate: 80%; the middle value lies on the limit itself.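

No step can be read between compound 2 and compound 3, as both sit at a limit and not at a number: the limit of > 30000 nM in this assay, at which 3 of the 3 values shown sit.

The compounds shown leave open where any of them truly lies in this assay, and whether 2-(methoxycarbonyl)ethenyl and 2-(methoxycarbonyl)ethyl differ at all.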